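This account rests on a few compounds, and the source may have more. Where it says the series, first, only, none or still open, it means among the compounds named here.

In a functional assay on RAW264.7 cells (Mus musculus) for inhibition, read by fluorescence, with stated times of 1 h, 24 h and 30 min (a higher number here means a weaker inhibitor, a lower number a stronger inhibitor), the measured compounds are:

- Compound 1 `O=C(/C=C/c1ccccc1F)c1ccccc1`: > 10000 nM
- Compound 2 `O=C(/C=C/c1ccccc1F)c1ccc(O)cc1`: > 10000 nM
- Compound 3 `O=C(/C=C/c1ccc(F)cc1)c1ccccc1`: > 10000 nM

Each of these entries is a limit and not a number, so the series offers only (the limit of > 10000 nM in this assay, at which 3 of the 3 values shown sit). Compound 2 therefore has no exact position, and its > 10000 nM is a limit too. Within the data shown here, the one measured step that bears on it is a step that the two limits leave unreadable from compound 1 to compound 2, so it gives no size to carry forward.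

Compound 4 `O=C(/C=C/c1ccccc1OC(F)(F)F)c1ccc(O)cc1` has trifluoromethoxy in place of fluoro on an aromatic carbon. Among the measured compounds shown here, no measured step covers this change, so any expectation in this assay is loose, with compound 4 likely to stay near that limit and possibly to report a limit again.

The expected change is a number no higher from compound 2 to compound 4 (the limit leaves the size open).

For compound 4 the estimated value is 10000 nM, with an expected range of 2500 nM to 30000 nM.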

Compound 4, half-maximal inhibitory concentration: 1340 nM
For compound 4 the middle estimate is 7.5-fold (0.87 log units) above the measured one; the whole stated range lies above it.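

In this assay, trifluoromethoxy in place of fluoro on an aromatic carbon ortho to a large group gives an at least 7.4-fold lower number from compound 2 to compound 4 (0.87 log units; beyond the scatter). Among these compounds, this is the only value shown that is an actual number, so this position can carry a change that brings measurable inhibition. Compound 2 reports only a limit, so the true size of the step remains unknown: the limit of > 10000 nM in this assay, at which 3 of the 4 values shown sit.

Going by these compounds, whether a methoxy group or a chlorine atom at this position would do the same remains open. The step for adding the hydroxy cannot be read, and the part that group plays in compound 4 is also unresolved.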